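This account rests on a few compounds, and the source may have more. Where it says the series, first, only, none or still open, it means among the compounds named here.

Measured in a functional assay on SW-620 cells (Homo sapiens) for cytotoxicity; on this read-out lower numbers stand for stronger inhibition and higher numbers for weaker inhibition:
Compound 2 `O=C(CCCCCCC(=O)Nc1nc2ccccc2s1)NO`: 4.01 ug/mL
Compound 1 `O=C(CCCCC(=O)Nc1nc2ccccc2s1)NO`: 7.85 ug/mL
Compound 3 `Cc1ccc2nc(NC(=O)CCCCC(=O)NO)sc2c1`: 4.69 ug/mL

Compound 2 has the lowest of these three numbers, but its gaps to compound 3 and to compound 1 both lie within the scatter, so the three cannot be ranked against one another. The unmeasured compound 4 `CCOc1ccc2nc(NC(=O)CCCCCCC(=O)NO)sc2c1` differs from compound 2 in one place: ethoxy in place of hydrogen on an aromatic carbon. Going by the values given here, the nearest precedent is another swap on an aromatic carbon of the shared core, a 1.7-fold lower number from compound 1 to compound 3 (0.22 log units; within the scatter). The other measured step, a 2.0-fold lower number from compound 1 to compound 2 (0.29 log units; within the scatter), concerns the chain and bears less directly. Compound 4 is therefore expected to show a step of a 1.1-fold lower number from compound 2 to compound 4 (0.06 log units; within the scatter), not beyond the scatter. The estimate for compound 4 is 3.5 ug/mL, with a range from 1.5 ug/mL to 8 ug/mL.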

Compound 4, half-maximal inhibitory concentration: 10.4 ug/mL
Estimate against measurement, compound 4: 3.0-fold (0.47 log units) below; the measured number lies above the stated range.
By their numbers in this assay, from the lowest: compounds 2, 3, 1 and 4 (each within the scatter of the next, the first and the last beyond it).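

In this assay, ethoxy on this aromatic carbon gives a 2.6-fold higher number from compound 2 to compound 4 (0.41 log units; beyond the scatter), the only single change shown here that lies beyond the scatter. The smaller methyl swap on the same kind of carbon, a 1.7-fold lower number from compound 1 to compound 3 (0.22 log units; within the scatter), gave no such readable change, so this position does not accept every group without consequence. Nothing available here explains the ethoxy step. Still open, going by these compounds, is how methoxy, an amine or a carboxylic acid on this carbon would read. Also open, on these data alone, is whether ethoxy would give a similar step on the chain of compound 1.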